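A Hydroxy-to-Cyano Swap Read by Cell Viability

The source may hold more compounds than are shown below. What is called first, only, known or untested is meant among the compounds shown, and "the series" means these compounds.

Three compounds that share one core were run in an ADME assay on J774 cells (Mus musculus) for cytotoxicity, read by MTT assay, with a stated time of 48 h, tested at 50 ug/mL; a lower number here means a stronger effect, a higher number a weaker effect of the compound at the concentration tested. Compound 1 `O=C(N/N=C/c1ccccc1O)c1cnccn1` gives 1% there. Compound 2 `O=C(N/N=C/c1cccc(O)c1)c1cnccn1`, built from the same atoms joined differently, gives 100% in this assay; how its core differs from that of compound 1 is not broken down here. Compound 3 `N#Cc1ccccc1/C=N/NC(=O)c1cnccn1` gives 92% in this assay.

For the measured compounds named here, only one pair of measured compounds differs in a single place. From compound 1 to compound 3 the change is cyano in place of hydroxy on an aromatic carbon and the step is a number 91 percentage points higher from compound 1 to compound 3 (beyond the scatter). The numbers of compound 2 and compound 3 lie within the scatter of each other, while compound 1 lies far below both.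

The unmeasured compound 4 `N#Cc1cccc(/C=N/NC(=O)c2cnccn2)c1` is related to compound 2 by cyano in place of hydroxy on an aromatic carbon. This is the same kind of change as that from compound 1 to compound 3, not the same change: in the first case the group sits ortho to a large group, in the second meta to a large group. Whether the large step seen from compound 1 to compound 3 carries over is open, as compound 2 already sits at the top of the range in this assay. With compound 2 at 100% and compound 3 at 92%, compound 4 is expected to give about 95% in this assay, between 80% and 100%. The expected step is therefore a number 5 percentage points lower from compound 2 to compound 4 (within the scatter), which is estimated to stay within the scatter.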

Compound 4, a percentage reported as activity, at one concentration (the size of the read-out at that concentration, not a potency): 100%
Compound 4: the middle estimate sits 5 percentage points below what was measured; the measured number falls inside the stated range.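

In this assay, cyano in place of hydroxy on an aromatic carbon, here meta to a large group, shows no change at the digits printed from compound 2 to compound 4 (within the scatter). Carried from the core of compound 1 to the core of compound 2, the change therefore does not keep its size: the same change on two cores in this assay, a number 91 percentage points higher (beyond the scatter) from compound 1 to compound 3 and no change at the digits printed (within the scatter) from compound 2 to compound 4, 91 percentage points apart, beyond the scatter of two such steps. For the compounds shown here, this shows that the large step seen on the core of compound 1 cannot be assumed for the same swap on the core of compound 2, but with only one pair on each core it does not show why the two steps part, nor how the change would behave on any further core.

The compounds shown leave open whether an amine, a methoxy group or a carboxylic acid on the same aromatic carbon would give a number close to that of compound 1 at 1% or close to that of compound 3 at 92%, and so whether the low number of compound 1 is tied to hydroxy alone. They also leave open how any of these compounds reads at a concentration other than the single one tested, since one concentration gives the size of a read-out and not a potency.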